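Aminopiperidine in Place of Imidazole: a Large Gain Expected

This account rests on a few compounds, and the source may have more. Where it says the series, first, only, none or still open, it means among the compounds named here.

Among the measured compounds shown here, compound 3 `COc1cc[nH]c1/C=C1\C(=O)Nc2ccc([N+](=O)[O-])c(-n3ccnc3)c21` gives 3920 nM in a functional assay on RKO cells (Homo sapiens) for antiproliferative activity, read by MTT assay, with a stated time of 5 days (a higher number here means a weaker inhibitor, a lower number a stronger inhibitor), the highest number among the compounds measured so far. Its nearest neighbour, compound 2 `COc1cc[nH]c1/C=C1\C(=O)Nc2ccc([N+](=O)[O-])cc21`, gives 692 nM, and the gap between them is a 5.7-fold higher number from compound 2 to compound 3 (0.75 log units; beyond the scatter). Compound 1 `COc1cc[nH]c1/C=C1\C(=O)Nc2ccc([N+](=O)[O-])c(N3CCC(O)CC3)c21`, bearing a 4-hydroxypiperidin-1-yl group, reaches only a limit of this assay at < 10 nM. The steps of an at least 69-fold higher number from compound 1 to compound 2 (1.84 log units; beyond the scatter) and an at least 390-fold higher number from compound 1 to compound 3 (2.59 log units; beyond the scatter) are both large. Compound 4 `COc1cc[nH]c1/C=C1\C(=O)Nc2ccc([N+](=O)[O-])c(N3CCC(N)CC3)c21` differs from compound 3 in one place: 4-aminopiperidin-1-yl in place of 1H-imidazol-1-yl on an aromatic carbon. Because 4-aminopiperidin-1-yl closely resembles the group in compound 1, whose result is the limit of < 10 nM in this assay, at which 1 of the 3 values shown sits, a large drop is expected, a 330-fold lower number from compound 3 to compound 4 (2.51 log units; beyond the scatter). Compound 4 is therefore estimated at 12 nM, within a range from 3 nM to 60 nM.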

Compound 4, half-maximal inhibitory concentration: < 10 nM
Compound 4: only a limit was reported; the forecaster's own chance of this, stated with the estimate: 40%; at least 1.2-fold (0.07 log units) between middle value and limit.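

Among the compounds shown here, the gain over hydrogen, so far seen only with 4-hydroxypiperidin-1-yl in compound 1, also holds with 4-aminopiperidin-1-yl on this aromatic carbon ortho to a nitro group: this assay shows an at least 69-fold lower number from compound 2 to compound 4 (1.84 log units; beyond the scatter), and against 1H-imidazol-1-yl it shows an at least 390-fold lower number from compound 3 to compound 4 (2.59 log units; beyond the scatter). Compound 4 gives < 10 nM, which is a limit of the assay. The step from compound 1 to compound 4, amino in place of hydroxy, cannot be read: the limit of < 10 nM in this assay, at which 2 of the 4 values shown sit.

Which of these two ring substituents gives the lower number remains open. So does how a morpholine ring, a piperazine ring or an open-chain amine would behave at this position.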